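Phenyl to thiophen-2-yl on the shared core

A few compounds are considered here, and "the series" means these few. Any claim that something is new, unique, unknown or untested is made for them only; others in the source may bear on it.

Values in a functional assay on MDA-MB-231 cells (Homo sapiens) for inhibition, read by sulforhodamine B assay, with a stated time of 48 h (a lower number here means a stronger inhibitor of growth, a higher number a weaker inhibitor of growth), so far:
- Compound 1 `c1ccc(-c2nc3ncccn3c2CN2CCCC2)cc1` gives 70 nM
- Compound 2 `c1ccc(-c2nc3ncccn3c2CN2CCCCC2)cc1` gives 30 nM
- Compound 3 `Cc1ccn2c(CN3CCCC3)c(-c3ccccc3)nc2n1` gives 4830 nM

Compound 1 holds the middle place among the three numbers, with compound 2 lower and compound 3 higher. The next structure is compound 4 `c1csc(-c2nc3ncccn3c2CN2CCCC2)c1` with thiophen-2-yl in place of phenyl on an aromatic carbon, and the counted difference is thiophen-2-yl in place of phenyl on an aromatic carbon in full. The measured steps bear on this change only indirectly. Replacing the saturated amine ring gave a 2.3-fold lower number from compound 1 to compound 2 (0.37 log units; beyond the scatter) and adding methyl to the core gave a 69-fold higher number from compound 1 to compound 3 (1.84 log units; beyond the scatter) as the largest move seen. Neither step was made at the carbon that carries phenyl, so the direction of any change is not measured. A step beyond the usual scatter is not expected for this exchange of one aromatic ring for another. The range stays wide since the core change in compound 3 gave a 69-fold higher number from compound 1 to compound 3 (1.84 log units; beyond the scatter) in this same assay. The expected step is a 1.3-fold higher number from compound 1 to compound 4 (0.11 log units; within the scatter) on this estimate. Compound 4 is expected at 90 nM in a range from 25 nM to 400 nM on this estimate.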

Compound 4, concentration for 50% growth inhibition: 200 nM
The estimate for compound 4 lay 2.2-fold (0.35 log units) below the measured number; low and high end bracket the measured number.
By their numbers in this assay, from the lowest: compound 2; then compound 1; then compound 4; then compound 3.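

The carbon next to the ring nitrogen, which bears the aryl group in these compounds, responds to the identity of that ring: in this assay, thiophen-2-yl in place of phenyl gives a 2.9-fold higher number from compound 1 to compound 4 (0.46 log units; beyond the scatter). This step lies beyond the scatter but remains much smaller than the methyl step on the shared core, a 69-fold higher number from compound 1 to compound 3 (1.84 log units; beyond the scatter). No measurement here accounts for the higher number.

Ring size and the sulfur change together in this step, so the share of each remains open; a furan-2-yl or pyridin-2-yl group at this carbon would bear on that. Also open, on these data alone, is how thiophen-2-yl behaves alongside the piperidin-1-yl group of compound 2.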